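The source may report more compounds than this note shows. Statements on the series, on what has been measured and on what is new or still open speak of the compounds shown alone.

Measured in an ADME assay on Huh-7 cells (Homo sapiens) for cytotoxicity, with a stated time of 72 h; on this read-out higher numbers stand for lower toxicity in this test and lower numbers for higher toxicity in this test:
Compound 1 `COCCn1nc(-c2cccs2)c(O)c(C2=NS(=O)(=O)c3cc(NS(C)(=O)=O)ccc3N2)c1=O`: > 1000 nM, a limit
Compound 2 `CC(C)Cn1nc(-c2cccs2)c(O)c(C2=NS(=O)(=O)c3cc(NS(C)(=O)=O)ccc3N2)c1=O`: > 1000 nM, a limit

Compound 2 stands only at a limit, > 1000 nM, and not at a number. Compound 3 `CS(=O)(=O)Nc1ccc2c(c1)S(=O)(=O)N=C(c1c(O)c(-c3cccs3)nn(Cc3ccccc3)c1=O)N2` differs from it as follows: phenyl in place of isopropyl on a saturated chain carbon bound to an aromatic nitrogen. In other words, phenyl takes the place of isopropyl on a saturated chain carbon bound to an aromatic nitrogen, so that isobutyl becomes benzyl. Among the measured compounds shown here, the one measured change at this place is a step that the two limits leave unreadable from compound 1 to compound 2. Both compounds sit at the same limit: the limit of > 1000 nM in this assay, at which 2 of the 2 values shown sit. No size of step can be read from these data. For the measured compounds named here, with a step that the two limits leave unreadable from compound 1 to compound 2 as the only guide, no step beyond the scatter is expected in this assay, and another reading at the limit is the likeliest result. The estimated step is a step that the limit leaves unreadable from compound 2 to compound 3. The estimate for compound 3 is 2000 nM, with an expected range from 800 nM to 10000 nM.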

Compound 3, half-maximal cytotoxic concentration: > 1000 nM
Compound 3 ended at the assay's limit (the forecaster's own chance of this, stated with the estimate: 85%); the middle value lies beyond the limit too.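

No size of step can be read among compound 1, compound 2 and compound 3 in this assay, since all of them stand at a limit and not at a number: the limit of > 1000 nM in this assay, at which 3 of the 3 values shown sit.

The compounds shown leave open whether phenyl in place of isopropyl, or any other change at this place, alters the cytotoxic concentration at all.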